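Capping the Phenol with a Methyl Group

The compounds below may be only part of what the source reports. "The series", "measured", "known", "first", "only" and "open" are said of these compounds alone.

The account follows three measured compounds and one still to be measured, all read in a functional assay on A549 cells (Homo sapiens) for antiproliferative activity, read by MTT assay, with a stated time of 24 h; a higher number here means a weaker inhibitor, a lower number a stronger inhibitor. Compound 1, `C=CCc1cc(-c2ccc(C(F)(F)F)cc2)ccc1O`, gives 76000 nM in this assay, the higher of the two results that came back as numbers. Compound 2, `C=CCc1cc(-c2ccccc2C(F)(F)F)ccc1O`, gives 59700 nM in this assay, a value that sits within the scatter of the value of compound 1, so no order between the two can be drawn. Compound 3, `C=CCc1cc(-c2cccc([N+](=O)[O-])c2)ccc1O`, returned only a limit in this assay, > 100000 nM. That outcome is the one described by the limit of > 100000 nM in this assay, at which 1 of the 3 values shown sits.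

Compound 4, `C=CCc1cc(-c2ccc(C(F)(F)F)cc2)ccc1OC`, awaits measurement in this assay. Set against compound 1 it carries methyl in place of hydrogen on an oxygen on an aromatic ring. Within the data shown here, no step between measured compounds is available to size this change, so the expectation rests on the values of the measured compounds alone.

Compound 4 is expected to give 100000 nM in this assay, with a range from 40000 nM to 250000 nM. The estimate implies a step of a 1.3-fold higher number from compound 1 to compound 4 (0.12 log units; within the scatter) in this assay, expected to be a modest weakening that may not exceed the scatter. A result that comes back only as a limit cannot be ruled out.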

Compound 4, half-maximal inhibitory concentration: > 100000 nM
Compound 4: only a limit was reported; the forecaster's own chance of this, stated with the estimate: 45%; the middle value sits exactly at the limit.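

Among these compounds, all the earlier compounds carry the hydroxy group, so the pair of compound 1 and compound 4 is the first look at a change on that oxygen, and the hydroxy to methoxy swap can be read only as a floor: an at least 1.3-fold higher number from compound 1 to compound 4 (0.11 log units; that floor lies within the scatter). In this assay, among the compounds shown here, compound 4 gives > 100000 nM, which is a limit and not a number, so the pair fixes no size for the step and does not show that capping the oxygen with methyl moves the result beyond the scatter. What the pair does add is that the methoxy compound yields no number in this assay, and the series now has as many limits as numbers: the limit of > 100000 nM in this assay, at which 2 of the 4 values shown sit.

Going by these compounds, how far the true value of compound 4 lies from that of compound 1 stays open, and so does whether the same swap would give a comparable step on compound 2. Also open, on these data alone, is how the result would read with a longer chain such as ethyl on the same oxygen, or with an amine in place of the hydroxy group.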